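The source may hold more compounds than are shown below. What is called first, only, known or untested is meant among the compounds shown, and "the series" means these compounds.

In a functional assay on HepG2 cells (Homo sapiens) for antiproliferative activity, read by MTT assay (on this read-out lower numbers stand for stronger inhibition and higher numbers for weaker inhibition), compound 1 `Cc1cccc(NC(=O)Nc2cccc(CNc3ncnc4ccccc34)c2)c1` gives > 50000 nM, which is a limit and not a number. Among the compounds with values here, compound 2 `CC(C)(C)c1ccc(NC(=O)Nc2cccc(CNc3ncnc4ccccc34)c2)cc1` gives 17000 nM, the only actual number so far. Within the data shown here, the one measured step is an at least 2.9-fold lower number from compound 1 to compound 2 (0.46 log units; beyond the scatter), and it starts from the limit noted in the limit of > 50000 nM in this assay, at which 1 of the 2 values shown sits. Compound 3 `O=C(Nc1cccc(Cl)c1)Nc1cccc(CNc2ncnc3ccccc23)c1` has 3-chlorophenyl in place of 4-(tert-butyl)phenyl on an amide-type nitrogen. This removes the group that gave an at least 2.9-fold lower number from compound 1 to compound 2 (0.46 log units; beyond the scatter), so part of that gain should be lost. The expected change is a 1.9-fold higher number from compound 2 to compound 3 (0.27 log units; within the scatter), a modest move to weaker inhibition. The estimate for compound 3 is 32000 nM, with an expected range of 14000 nM to 50000 nM.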

Compound 3, half-maximal inhibitory concentration: > 50000 nM
Compound 3 was reported as a limit; the forecaster's own chance of this, stated with the estimate: 45%; middle value at least 1.5-fold (0.19 log units) from the limit.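

With 3-chlorophenyl in place of 4-(tert-butyl)phenyl on the amide-type nitrogen, the result is an at least 2.9-fold higher number from compound 2 to compound 3 (0.46 log units; beyond the scatter), so the lower number of compound 2 does not carry over to this group. Compound 3 gives a limit and not a number, and the step from compound 1 to compound 3 cannot be read. Of the three groups shown on this nitrogen, only 4-(tert-butyl)phenyl gives an actual number in this assay, and the rest of the series stands at: the limit of > 50000 nM in this assay, at which 2 of the 3 values shown sit.

Whether the tert-butyl group itself accounts for the number of compound 2 stays open. Also open, going by these compounds, is how an amine or a carboxylic acid on this phenyl ring would read.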